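A few compounds are considered here, and "the series" means these few. Any claim that something is new, unique, unknown or untested is made for them only; others in the source may bear on it.

Compound 1, `O=C1/C(=C\c2cccc(Oc3ccccc3)c2)c2ccccc2N1c1c(Cl)cccc1Cl`: in a functional assay on MIA PaCa-2 cells (Homo sapiens) for cytotoxicity, read by MTT assay, with a stated time of 72 h (a lower number here means that less compound is needed, a higher number that more compound is needed for the effect), compound 1 gives > 100 ug/mL, which is a limit of the assay and not a number.
Compound 2, `O=C1/C(=C\c2ccccc2Cl)c2ccccc2N1c1c(Cl)cccc1Cl`: compound 2 gives > 100 ug/mL, again a limit rather than a number.
Compound 3, `COc1ccc(/C=C2\C(=O)N(c3c(Cl)cccc3Cl)c3ccccc32)cc1OC`: compound 3 gives 5 ug/mL.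

Compound 2 therefore stands at the limit of > 100 ug/mL in this assay, at which 2 of the 3 values shown sit; its value is only a ceiling, so nothing is known about how far beyond it the true figure lies. Compound 4, `CN(C)c1ccc(/C=C2\C(=O)N(c3c(Cl)cccc3Cl)c3ccccc32)cc1`, has not been measured in this assay. It differs from compound 2 in one place: 4-(dimethylamino)phenyl in place of 2-chlorophenyl on a double-bonded chain carbon bound to a double-bonded ring carbon. Within the data shown here, no measured pair in this set differs in a single place, so no step is recorded. Still, compound 3, which also carries an oxygen- or nitrogen-bearing aryl group on the same chain carbon, gives 5 ug/mL, and on that footing a downward step well beyond the scatter is expected for compound 4. The estimate for compound 4 is 8 ug/mL, with a range from 2 ug/mL to 40 ug/mL, corresponding to an expected step of an at least 12-fold lower number from compound 2 to compound 4 (1.09 log units; beyond the scatter).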

Compound 4, concentration for half-maximal effect: > 100 ug/mL
Compound 4 ended at the assay's limit; the forecaster's own chance of this, stated with the estimate: 25%; at least 12-fold (1.09 log units) between middle value and limit.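

In this assay compound 4 gives > 100 ug/mL, which is a limit and not a number. Compound 2 also stands at a limit, so no step can be read between compound 2 and compound 4. The compounds shown leave open whether 4-(dimethylamino)phenyl in place of 2-chlorophenyl changes the true figure at all.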